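Aryl swap at the saturated ring carbon of the core

The source may hold more compounds than are shown below. What is called first, only, known or untested is meant among the compounds shown, and "the series" means these compounds.

Compound 1 `N#CC1=C(N)OC(c2c[nH]c3ccccc23)=C(C#N)C1c1ccc2ccccc2c1` carries a naphthalen-2-yl group on a saturated ring carbon of the shared core; in a functional assay, tested at 50 ug/mL (a higher number here means a stronger effect of the compound at the concentration tested, a lower number a weaker effect), compound 1 gives "not active" (no number reported), so no number places it on the scale. The other aryl variants of the core stay low: compound 2 `CN(C)c1ccc(C2C(C#N)=C(N)OC(c3c[nH]c4ccccc34)=C2C#N)cc1` gives 14.4% and compound 3 `Cc1ccc(C2C(C#N)=C(N)OC(c3c[nH]c4ccccc34)=C2C#N)cc1` gives 5.2%, and the step of a number 9.2 percentage points lower from compound 2 to compound 3 (within the scatter) stays within the scatter. Compound 4 `N#CC1=C(N)OC(c2c[nH]c3ccccc23)=C(C#N)C1c1ccccc1Cl` differs from compound 1 by 2-chlorophenyl in place of naphthalen-2-yl on a saturated ring carbon. Among the compounds with values here, no measured step covers this change; the one measured step concerns a group on an aromatic carbon, not the aryl ring itself, so it bears on it only loosely. A step in this assay beyond the scatter is not expected. For compound 4 the estimate in this assay is 8%, range 0% to 20%.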

Compound 4, a percentage reported as activity, at one concentration (the size of the read-out at that concentration, not a potency): 8.5%
Estimate against measurement, compound 4: 0.5 percentage points below; measured number inside the range.
By their numbers in this assay, from the lowest: compounds 3, 4 and 2 (each within the scatter of the next).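

In this assay the change to 2-chlorophenyl gives a number 3.3 percentage points higher from compound 3 to compound 4 (within the scatter) and a number 5.9 percentage points lower from compound 2 to compound 4 (within the scatter) and so shows that a phenyl ring bearing chlorine on this saturated ring carbon reads level with 4-methylphenyl and 4-(dimethylamino)phenyl. The step from compound 1 to compound 4 cannot be read, as compound 1 has no number. Nothing at hand accounts for this flat reading.

Open, going by these compounds, is whether a phenyl ring carrying a carboxylic acid or a hydroxyl group would lift the read-out at this carbon. Also open, on these data alone, is whether a saturated amine in place of the aryl ring would do so.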